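A few compounds are considered here, and "the series" means these few. Any claim that something is new, unique, unknown or untested is made for them only; others in the source may bear on it.

Measured compounds:
- compound 1, `COc1nc(C2=NOCC(c3ccccc3)N2)ccc1-n1cnc(C)c1`, 21 mL/min/kg
- compound 2, `COc1nc(C2=NOCC(c3ccc(Cl)cc3)N2)ccc1-n1cnc(C)c1`, 2 mL/min/kg
- compound 3, `COc1nc(C2=NOCC(c3ccc(Cl)c(F)c3)N2)ccc1-n1cnc(C)c1`, 32 mL/min/kg

In an ADME assay on cells (Hepatocyte, Homo sapiens) for pharmacokinetics (on this read-out higher numbers stand for fast clearance and lower numbers for slow clearance), compound 1 stands second highest of the three numbers; compound 3 lies nearest to it, a 1.5-fold higher number from compound 1 to compound 3 (0.18 log units; within the scatter), while compound 2 lies furthest, an 11-fold lower number from compound 1 to compound 2 (1.02 log units; beyond the scatter).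

The unmeasured compound 4, `COc1nc(C2=NOCC(c3cc(Cl)cc(Cl)c3)N2)ccc1-n1cnc(C)c1`, differs from compound 1 in one place: 3,5-dichlorophenyl in place of phenyl on a saturated ring carbon.

Among the compounds with values here, two measured steps bear on this change. Adding a single chloro to the phenyl gave a large drop, an 11-fold lower number from compound 1 to compound 2 (1.02 log units; beyond the scatter). Yet a further fluoro on that same ring reversed it, a 16-fold higher number from compound 2 to compound 3 (1.20 log units; beyond the scatter), so that the doubly substituted ring of compound 3 sits close to the bare phenyl of compound 1, a 1.5-fold higher number from compound 1 to compound 3 (0.18 log units; within the scatter). Within the data shown here, two chlorines in the 3,5-pattern of compound 4 have no direct precedent here. Since one chloro lowered the number and a second halogen raised it again, a modest lowering is expected for compound 4, a 2.1-fold lower number from compound 1 to compound 4 (0.32 log units; beyond the scatter), with wide uncertainty. In this assay compound 4 is estimated at 10 mL/min/kg, within a range from 3 mL/min/kg to 35 mL/min/kg.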

Compound 4, clearance: 85 mL/min/kg
Beside the measured number, compound 4's estimate is 8.5-fold (0.93 log units) below it; measured number outside the range, above it.
By their numbers in this assay, from the lowest: compound 2; then compounds 1 and 3 (each within the scatter of the next); then compound 4.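

In this assay, the 3,5-dichlorophenyl group gives the highest number of the four compounds (a 4.0-fold higher number from compound 1 to compound 4 (0.61 log units; beyond the scatter)), so the large fall seen with a single chloro does not carry over to every chlorinated ring at this saturated ring carbon. Within the data shown here, the same group also stands clear of both other halogenated rings (a 2.7-fold higher number from compound 3 to compound 4 (0.42 log units; beyond the scatter); a 43-fold higher number from compound 2 to compound 4 (1.63 log units; beyond the scatter)), which leaves compound 2, with its 4-chlorophenyl group, as the only low number in the set, while compound 3 and compound 4 go against any rule that halogens on this ring lower the number. The data shown offer no explanation for why these closely related rings give such different numbers.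

The compounds shown do not separate the effect of the number of halogens from the effect of where they sit on the ring, since no ring here carries a single chloro anywhere other than in the 4-chlorophenyl group. As far as these compounds go, whether the low number of compound 2 can be kept with a group other than a halogen on the ring, such as a methoxy, a nitrile, an amine or a carboxylic acid, also remains open.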